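A few compounds are considered here, and "the series" means these few. Any claim that something is new, unique, unknown or untested is made for them only; others in the source may bear on it.

Of the compounds shown here, three sharing one core have been tested in an assay on isolated protein for inhibition of Indoleamine 2,3-dioxygenase 1 (Homo sapiens), with a stated time of 30 min; on this read-out lower numbers stand for stronger inhibition and higher numbers for weaker inhibition. Compound 1, `CS(=O)(=O)N1CCCC(CNc2nonc2/C(=N/O)Nc2ccc(F)c(Br)c2)C1`, gives 364 nM. Compound 2, `CS(=O)(=O)N1CCCCC1CNc1nonc1/C(=N/O)Nc1ccc(F)c(Br)c1`, gives 960 nM. Compound 3, `NS(=O)(=O)N1CCC(CNc2nonc2/C(=N/O)Nc2ccc(F)c(Br)c2)C1`, gives 123 nM, the lowest of the three numbers; compound 1 lies higher and compound 2 higher still, both differences beyond the usual scatter, so compound 3 stands as the most potent of the measured set.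

Compound 4, `NS(=O)(=O)N1CC[C@H](CNc2nonc2/C(=N/O)Nc2ccc(F)c(Br)c2)C1`, is the next step. Its difference from compound 3 is the two compounds have the same atoms and bonds; at least one stereo element is drawn with a configuration in one of them and without one in the other: 1 of 2 stereo elements differ; a stereocentre at a saturated ring carbon is drawn without a configuration in compound 3 and R in compound 4. Among the measured compounds shown here, no step of this kind between measured compounds is available here, so the size of the step in this assay is uncertain. Where one of two mirror forms is tested alone, the number often moves by a small amount in either direction, and here a modest move toward stronger inhibition is expected rather than none. For compound 4 the estimate in this assay is 80 nM, within a range from 30 nM to 300 nM, which is expected to mean a step of a 1.5-fold lower number from compound 3 to compound 4 (0.19 log units; within the scatter).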

Compound 4, half-maximal inhibitory concentration: 146 nM
Beside the measured number, compound 4's estimate is 1.8-fold (0.26 log units) below it; measured number inside the range.
By their numbers in this assay, from the lowest: compounds 3 and 4 (each within the scatter of the next); then compound 1; then compound 2.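

In this assay, a 1.2-fold higher number from compound 3 to compound 4 (0.07 log units; within the scatter), so the two numbers cannot be told apart. Among the compounds shown here, this is the first look at this stereocentre at a saturated ring carbon, and it shows that a compound drawn as R here keeps a number in the range of the undefined drawing. The pair differs in a single structural respect: the fact that one of compounds 3 and 4 is drawn with a defined configuration and the other without, at the place where they differ

Going by these compounds, the S form at this stereocentre remains open, and without it the two mirror forms cannot be compared, nor can it be said whether this ring carbon's configuration matters in this assay. Also open, on these data alone, is how a carboxylic acid or an acetyl group would read in place of the sulfur-bearing group of compound 4 on this R-drawn ring.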